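Changing the aryl group on the triazole: an expected outcome

A few compounds are considered here, and "the series" means these few. Any claim that something is new, unique, unknown or untested is made for them only; others in the source may bear on it.

Compound 1 `COc1ccc(-n2nncc2CN2C(=O)C3(C(C#N)=C(N)Oc4c(N)cc5nc6ccccc6nc5c43)c3ccccc32)cc1` gives in a functional assay on HepG2 cells (Homo sapiens) for antiproliferative activity, read by MTT assay, with a stated time of 48 h (a lower number here means a stronger inhibitor, a higher number a weaker inhibitor), only the limit > 50000 nM. Compound 2 `N#CC1=C(N)Oc2c(N)cc3nc4ccccc4nc3c2C12C(=O)N(Cc1cnnn1-c1ccc([N+](=O)[O-])cc1)c1ccccc12` likewise gives in this assay only the limit > 50000 nM.

Compound 2 therefore stands at the limit of this assay, as does the other measured compound: the limit of > 50000 nM in this assay, at which 2 of the 2 values shown sit. The step that the two limits leave unreadable from compound 1 to compound 2 cannot be read, since both ends are limits rather than numbers. The next compound, compound 3 `N#CC1=C(N)Oc2c(N)cc3nc4ccccc4nc3c2C12C(=O)N(Cc1cnnn1-c1cc(Cl)ccc1Cl)c1ccccc12`, differs from compound 2 in one place: 2,5-dichlorophenyl in place of 4-nitrophenyl on an aromatic nitrogen. For the measured compounds named here, the only measured step is the unreadable one from compound 1 to compound 2, so no measured step sets a size or direction for the change to compound 3; two compounds with different aryl groups on this nitrogen both sit at the limit. The expected step is a step that the limit leaves unreadable from compound 2 to compound 3, with a limit again the likeliest report. Compound 3 is thus estimated at 60000 nM, within 15000 nM to 250000 nM.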

Compound 3, half-maximal inhibitory concentration: 33100 nM
Beside the measured number, compound 3's estimate is 1.8-fold (0.26 log units) above it, within the range that was stated.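

For the compounds shown here, with 2,5-dichlorophenyl on the aromatic nitrogen, compound 3 is the first compound here to give a measured number rather than a limit in this assay, so a value at this position can now be read. From the compounds shown here alone, replacing the aryl group gives an at least 1.5-fold lower number from compound 2 to compound 3 (0.17 log units; that floor lies within the scatter), and an at least 1.5-fold lower number from compound 1 to compound 3 (0.17 log units; that floor lies within the scatter); both steps are only floors, so their true sizes remain unknown. Limits still account for most of the values shown: the limit of > 50000 nM in this assay, at which 2 of the 3 values shown sit.

The compounds shown leave open whether a single chlorine on the phenyl ring would also give a measured number, or whether both chlorines are needed. They also leave open how a benzyl group or a cyclohexyl ring would behave on this nitrogen.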